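Nitro-to-methyl exchange on the aryl imine of compound 2

The source may hold more compounds than are shown below. What is called first, only, known or untested is meant among the compounds shown, and "the series" means these compounds.

Compound 2 `CC(=O)Nc1ccc(S(=O)(=O)NC(C)c2nc3ccccc3c(=O)n2/N=C/c2ccc([N+](=O)[O-])cc2)cc1` gives 0.044 ug/mL in an assay for inhibition of Dihydrofolate reductase (Bos taurus), with a stated time of 2 min (on this read-out lower numbers stand for stronger inhibition and higher numbers for weaker inhibition), and it carries the lower of the two numbers recorded so far. Among the measured compounds shown here, its nearest neighbour is compound 1 `CC(=O)Nc1ccc(S(=O)(=O)NC(C)c2nc3ccccc3c(=O)n2/N=C/c2cccc([N+](=O)[O-])c2)cc1`, which in this assay gives 0.053 ug/mL; the only one-point step available, a 1.2-fold lower number from compound 1 to compound 2 (0.08 log units; within the scatter), is a positional shift of the nitro group and lies within the scatter.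

Compound 3 `CC(=O)Nc1ccc(S(=O)(=O)NC(C)c2nc3ccccc3c(=O)n2/N=C/c2ccc(C)cc2)cc1` is the next member. It differs from compound 2 by methyl in place of nitro on an aromatic carbon; read one bond further out, this is 4-nitrophenyl to 4-methylphenyl.

For the measured compounds named here, no measured step bears directly on this exchange. Going by the values given here, the single recorded step concerns only where the nitro sits, not its presence, and it was within the scatter, so it offers no direction for a replacement by methyl. The expectation for compound 3 is therefore centred near the value of compound 2, with a range wide enough to admit a real step either way; the estimated step is a 1.6-fold higher number from compound 2 to compound 3 (0.20 log units; within the scatter). Compound 3 is estimated at 0.07 ug/mL in this assay, with a range from 0.02 ug/mL to 0.25 ug/mL.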

Compound 3, half-maximal inhibitory concentration: 0.083 ug/mL
Compound 3: the middle estimate sits 1.2-fold (0.07 log units) below what was measured; the measured number falls inside the stated range.
By their numbers in this assay, from the lowest: compounds 2, 1 and 3 (each within the scatter of the next).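

Exchange of nitro for methyl on this aromatic carbon, para to a large group, reads in this assay as a 1.9-fold higher number from compound 2 to compound 3 (0.28 log units; within the scatter), so the presence of the nitro group at this position is not required to stay within the scatter of compound 2. The 3-nitrophenyl member gives the same picture, with a 1.6-fold higher number from compound 1 to compound 3 (0.19 log units; within the scatter), which extends the earlier finding: the first step only moved the nitro group, whereas these two steps replace it, and 4-methylphenyl still does not separate from either nitro compound. No measurement on hand speaks to what lies behind the size of these steps.

From the compounds shown here alone, since nitro and methyl differ in heavy atoms and hydrogen-bond acceptors yet give steps inside the scatter, it remains open whether any group on this aromatic carbon can move the number beyond it. An amine, a carboxylic acid or a plain hydrogen here, or a longer chain in place of methyl, would show whether this position responds at all or whether the number is set by the shared core.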